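Naphthalen-2-yl in place of 4-methoxyphenyl: tolerated concentration outlook

A few compounds are considered here, and "the series" means these few. Any claim that something is new, unique, unknown or untested is made for them only; others in the source may bear on it.

Compound 1, `O[C@@H]1[C@@H](O)[C@H](c2ccccc2)O[C@@H]2CO[C@@H](c3ccc(Cl)cc3)O[C@@H]12`: in a functional assay on HEL cells (Homo sapiens) for cytotoxicity (a higher number here means that more compound is tolerated, a lower number that less compound is tolerated), compound 1 gives >= 100 ug/mL, which is a limit of the assay rather than a number.
Compound 2, `COc1ccc([C@@H]2OC[C@H]3O[C@@H](c4ccccc4)[C@H](OC)[C@@H](OC)[C@@H]3O2)cc1`: in this assay compound 2 gives "not determined" (no result reported), that is, no result is reported for it.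
Compound 3, `CO[C@@H]1[C@@H](OC)[C@H](c2ccccc2)O[C@@H]2CO[C@@H](c3ccc(-c4ccccc4)cc3)O[C@@H]12`: in this assay compound 3 gives >= 16 ug/mL, again a limit rather than a number.

Compound 2 therefore stands nowhere on the numbers shown; the other two compounds sit at limits, one at the limit of >= 100 ug/mL in this assay, at which 1 of the 3 values shown sits, and one at the limit of >= 16 ug/mL in this assay, at which 1 of the 3 values shown sits. The new compound 4, `CO[C@@H]1[C@@H](OC)[C@H](c2ccccc2)O[C@@H]2CO[C@@H](c3ccc4ccccc4c3)O[C@@H]12`, differs from compound 2 by naphthalen-2-yl in place of 4-methoxyphenyl on a saturated ring carbon. Among the measured compounds shown here, with no measured step from compound 2, no direction can be read off; compound 4 shares more of its remaining structure with compound 3 than with compound 1. Compound 4 is therefore expected to fall around 20 ug/mL, within 5 ug/mL to 100 ug/mL, in this assay.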

Compound 4, minimum cytotoxic concentration: >= 16 ug/mL
Compound 4 gave a limit, no number (the forecaster's own chance of this, stated with the estimate: 60%); the middle value does not contradict the limit.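

In this assay compound 4 gives >= 16 ug/mL, a limit and not a number. Among the compounds shown here, compound 2 has no reported result, and no step from it to compound 4 can be read. The compounds shown leave open whether naphthalen-2-yl in place of 4-methoxyphenyl changes the tolerated concentration.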